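A few compounds are considered here, and "the series" means these few. Any claim that something is new, unique, unknown or untested is made for them only; others in the source may bear on it.

Compound 1 `O=C(/C=C/c1ccc(O)c(O)c1)N1CCN(c2ccc(F)cc2)CC1` and compound 2 `COc1cccc(N2CCN(C(=O)/C=C/c3ccc(O)c(O)c3)CC2)c1` share one core and differ only in the group on an amine nitrogen in a ring. In a functional assay on B16-F10 cells (Mus musculus) for antiproliferative activity, read by MTT assay, with a stated time of 48 h (on this read-out lower numbers stand for stronger inhibition and higher numbers for weaker inhibition), compound 1 gives 1.68 ug/mL, and compound 2 gives 1.46 ug/mL, the lower of the two numbers, though the step of a 1.2-fold lower number from compound 1 to compound 2 (0.06 log units; within the scatter) shows the gap to be within the scatter. Compound 3 `O=C(/C=C/c1ccc(O)c(O)c1)N1CCN(c2ccccn2)CC1` carries the change (pyridin-2-yl in place of 3-methoxyphenyl on an amine nitrogen in a ring). For the measured compounds named here, the one measured step, also a swap of the group at that place, stayed within the scatter, so only a small step, if any, is expected: a 1.1-fold higher number from compound 2 to compound 3 (0.04 log units; within the scatter). Compound 3 is therefore estimated at 1.6 ug/mL, within 0.8 ug/mL to 3.4 ug/mL.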

Compound 3, half-maximal inhibitory concentration: 3.01 ug/mL
Estimate against measurement, compound 3: 1.9-fold (0.27 log units) below; the range from low to high includes it.
By their numbers in this assay, from the lowest: compounds 2, 1 and 3 (each within the scatter of the next, the first and the last beyond it).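

In this assay, this place on the ring amine nitrogen now shows a swap that passes the usual scatter: a 2.1-fold higher number from compound 2 to compound 3 (0.31 log units; beyond the scatter) is modest, and it comes with pyridin-2-yl entering for 3-methoxyphenyl. The same pyridin-2-yl entering for 4-fluorophenyl gives a 1.8-fold higher number from compound 1 to compound 3 (0.25 log units; within the scatter) and stays within the scatter, so the size of the shift depends on which group leaves. Nothing measured here accounts for this shift. As far as these compounds go, whether a benzyl or a methyl group at this place would move the number further remains open.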